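The compounds below may be only part of what the source reports. "The series", "measured", "known", "first", "only" and "open" are said of these compounds alone.

Measured so far: compound 1 `CCC/C=C\C(=O)Nc1cc(Nc2nc(C)cc(-c3cn(C)c4ccccc34)n2)c(OC)cc1N(C)CCN(C)C` gives 254 nM in a functional assay on NCI-H1975 cells (Homo sapiens) for antiproliferative activity, read by MTT assay, with a stated time of 72 h; on this read-out lower numbers stand for stronger inhibition and higher numbers for weaker inhibition; compound 2 `C=CC(=O)Nc1cc(Nc2nc(C)cc(-c3cn(C)c4ccc(F)cc34)n2)c(OC)cc1N(C)CCN(C)C` gives 3830 nM; compound 3 `CC/C=C\C(=O)Nc1cc(Nc2nc(C)cc(-c3cn(C)c4ccc(F)cc34)n2)c(OC)cc1N(C)CCN(C)C` gives 10400 nM.

Compound 3 has the highest number of the three, with compound 2 nearest and compound 1 furthest away. The new compound 4 `CCC/C=C\C(=O)Nc1cc(Nc2nc(C)cc(-c3cn(C)c4ccc(F)cc34)n2)c(OC)cc1N(C)CCN(C)C` differs from compound 3 by methyl in place of hydrogen on a saturated chain carbon, two bonds along the chain from a double-bonded chain carbon, so the chain on the carbonyl grows from but-1-en-1-yl to pent-1-en-1-yl. Within the data shown here, the only measured step that bears on chain length is a 2.7-fold higher number from compound 2 to compound 3 (0.43 log units; beyond the scatter), where lengthening the chain raised the number. Compound 1 carries the same pent-1-en-1-yl chain on a core that differs from that of compound 4, and its much lower value cannot be separated into the two differences. Among the measured compounds shown here, with one modest step pointing upward and no step for the further extension, a small change in either direction is plausible. Compound 4 is therefore expected at about 9000 nM, within 2500 nM to 30000 nM, which means an expected step of a 1.2-fold lower number from compound 3 to compound 4 (0.06 log units; within the scatter).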

Compound 4, half-maximal inhibitory concentration: 12200 nM
Compound 4: middle estimate off by 1.4-fold (0.13 log units), on the low side; low and high end bracket the measured number.
By their numbers in this assay, from the lowest: compound 1; then compound 2; then compounds 3 and 4 (each within the scatter of the next).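

In this assay, the added methyl gives a 1.2-fold higher number from compound 3 to compound 4 (0.07 log units; within the scatter), so but-1-en-1-yl and pent-1-en-1-yl cannot be told apart at this position, while pent-1-en-1-yl in place of vinyl gives a 3.2-fold higher number from compound 2 to compound 4 (0.50 log units; beyond the scatter), which puts both longer chains above vinyl on the fluorinated core. Compound 4 also pairs with compound 1, which carries the same chain, and this isolates the fluoro group: fluoro in place of hydrogen on an aromatic carbon gives a 48-fold higher number from compound 1 to compound 4 (1.68 log units; beyond the scatter), by far the largest step in this set. Nothing available here explains these numbers.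

On these data alone, whether the fluoro step would be as large with vinyl or but-1-en-1-yl on the carbonyl carbon remains open. So does how a longer chain, or a chain carrying an amine, would read in this assay.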